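A few compounds are considered here, and "the series" means these few. Any claim that something is new, unique, unknown or untested is made for them only; others in the source may bear on it.

Compound 1 `O=C1c2ccccc2CN1c1cnc(NCc2c(F)ccc3c2CCO3)n2cnnc12`, compound 2 `Fc1ccc2c(c1CNc1ncc(Oc3ccccc3)c3nncn13)CCO2` and compound 3 `Fc1ccc2c(c1CNc1ncc(Nc3ccccc3)c3nncn13)CCO2` share one core and differ only in the group on one aromatic carbon. In a physicochemical assay for lipophilicity, using the shake flask method, in phosphate buffer, measured as octanol-water partition, with a stated time of 30 min, at pH 7.4 (a higher number here means a more lipophilic compound, a lower number a more polar compound), compound 1 gives 2.7, compound 2 gives 3.5 and compound 3 gives 3.3, which places compound 3 second highest of the three. The steps of a number 0.60 log units higher from compound 1 to compound 3 (beyond the scatter) and a number 0.20 log units lower from compound 2 to compound 3 (within the scatter) are measured. Compound 4 `CN(c1ccn(C)n1)c1cnc(NCc2c(F)ccc3c2CCO3)n2cnnc12` carries a different group: methyl(1-methyl-1H-pyrazol-3-yl)amino in place of anilino on an aromatic carbon. Among the compounds with values here, no measured step swaps anilino for this group, so the expectation rests on the change itself, which removes the carbon-only aromatic ring and brings in the pyrazole-bearing amino group. A modest fall is therefore expected, a number 0.60 log units lower from compound 3 to compound 4 (beyond the scatter), giving compound 4 an estimated 2.7 (range 2.1 to 3.3).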

Compound 4, distribution coefficient: 1.8
Compound 4: middle estimate off by 0.90 log units, on the high side; the measured number lies below the stated range.
By their numbers in this assay, from the lowest: compound 4; then compound 1; then compounds 3 and 2 (each within the scatter of the next).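

In this assay, swapping in methyl(1-methyl-1H-pyrazol-3-yl)amino gives a number 1.50 log units lower from compound 3 to compound 4 (beyond the scatter) and a number 1.70 log units lower from compound 2 to compound 4 (beyond the scatter), both large, and the comparison with the bulkier group of compound 1 still gives a number 0.90 log units lower from compound 1 to compound 4 (beyond the scatter). Of these four compounds, only compound 4 has no six-membered aromatic ring of carbon only at this position, and it has the lowest number. Nothing measured here explains the fall. As far as these compounds go, the change replaces the ring and adds a methyl on the amino nitrogen at once, so the share of each stays open. A methyl(phenyl)amino group would keep the carbon-only ring while carrying that methyl.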